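A few compounds are considered here, and "the series" means these few. Any claim that something is new, unique, unknown or untested is made for them only; others in the source may bear on it.

In a functional assay (trachea) with Cavia porcellus as the target (a higher number here means that more compound is needed for the effect, a lower number that less compound is needed), compound 1 `CCCn1c(=O)n(CC)c(=O)c2[nH]cnc21` gives 1300 nM, and compound 2 `CCCn1c(=O)n(CCN(C)C)c(=O)c2[nH]cnc21` gives 2700 nM. Compound 3 `CCCn1c(=O)n(C)c(=O)c2c1ncn2CC(N)=O` gives no number, only a limit of the assay, > 100000 nM. It alone stands at the limit of > 100000 nM in this assay, at which 1 of the 3 values shown sits. Compound 4 `CCCn1c(=O)n(C)c(=O)c2c1ncn2CCOCC` keeps the core of compound 3 and changes one group ethoxymethyl in place of carbamoyl on a saturated chain carbon bound to an aromatic nitrogen. Among the measured compounds shown here, only one measured step bears on this, and only loosely. It is a 2.1-fold higher number from compound 1 to compound 2 (0.32 log units; beyond the scatter), with dimethylamino in place of hydrogen on a saturated chain carbon, two bonds along the chain from an aromatic nitrogen. That step moved the number only modestly, but it is a different change from this one. A measurable number for compound 4 can only lie lower than the limit of compound 3, so a large step to a lower number is expected in this assay. The expected step is an at least 6.6-fold lower number from compound 3 to compound 4 (0.82 log units; beyond the scatter). For compound 4 the estimated value is 15000 nM, with an expected range from 3000 nM to 80000 nM.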

Compound 4, half-maximal effective concentration: 4600 nM
The estimate for compound 4 lay 3.3-fold (0.51 log units) above the measured number; the range from low to high includes it.
By their numbers in this assay, from the lowest: compound 1; then compounds 2 and 4 (each within the scatter of the next). At a limit, above all of these: compound 3.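

On the saturated chain carbon bound to an aromatic nitrogen, putting ethoxymethyl in place of carbamoyl gives a measurable number in this assay, with an at least 21-fold lower number from compound 3 to compound 4 (1.33 log units; beyond the scatter). Among the compounds shown here, the only earlier step was a modest one from a different change, so this is the first sign that the group in this place can move the number a long way. Compound 3 gives a limit and not a number, so the printed size of the step is only a minimum: the limit of > 100000 nM in this assay, at which 1 of the 4 values shown sits.

Carbamoyl and ethoxymethyl differ in several counted ways at once, including the hydrogen-bond donor that only carbamoyl carries, and the compounds shown do not separate these. As far as these compounds go, how an amine, a carboxylic acid or a longer chain would fare in this place also remains open.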